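Aryl ether in place of benzyl on the shared core

The compounds below may be only part of what the source reports. "The series", "measured", "known", "first", "only" and "open" are said of these compounds alone.

Three compounds share one core and differ only in the group attached to it. Compound 1 `COc1ccc(F)cc1CNCCCNc1ccnc2cc(CCC(C)C)ccc12` carries an isobutyl group, and in an ADME assay on HepG2 cells (Homo sapiens) for cytotoxicity, read by luminescence, CellTiter-Glo and ATP content, with a stated time of 72 h (on this read-out higher numbers stand for an effect only at larger amounts of compound and lower numbers for an effect already at smaller amounts), compound 1 gives 890 nM. Compound 2 `COc1ccc(F)cc1CNCCCNc1ccnc2cc(Cc3ccc(F)cc3)ccc12` gives 3530 nM, and compound 3 `COc1ccc(F)cc1CNCCCNc1ccnc2cc(Cc3ccc(F)cc3Cl)ccc12` gives 2460 nM. Compound 3 thus stands second highest of the three numbers: the step of a 1.4-fold lower number from compound 2 to compound 3 (0.16 log units; within the scatter) lies within the scatter, whereas the step of a 2.8-fold higher number from compound 1 to compound 3 (0.44 log units; beyond the scatter) lies beyond it, as does a 4.0-fold higher number from compound 1 to compound 2 (0.60 log units; beyond the scatter).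

Compound 4 `COc1ccc(F)cc1CNCCCNc1ccnc2cc(Oc3ccc(F)cc3)ccc12` has not yet been measured. 4-fluorophenoxy in place of 2-chloro-4-fluorobenzyl on an aromatic carbon Two parts of this change can be read against the measured steps. Taking away the chloro reverses the step of a 1.4-fold lower number from compound 2 to compound 3 (0.16 log units; within the scatter), which was within the scatter, so on its own it should move compound 4 back toward compound 2. The replacement of the saturated chain carbon by an oxygen linking the ring has no measured counterpart among these compounds, so nothing is known of its size or direction. Compound 4 is therefore expected to land close to compound 2, with an estimated step of a 1.2-fold higher number from compound 3 to compound 4 (0.09 log units; within the scatter) that is not clearly beyond the scatter. The estimate for compound 4 in this assay is 3000 nM, expected between 1200 nM and 8000 nM.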

Compound 4, half-maximal effective concentration: 6600 nM
For compound 4 the middle estimate is 2.2-fold (0.34 log units) below the measured one; measured number inside the range.
By their numbers in this assay, from the lowest: compound 1; then compounds 3, 2 and 4 (each within the scatter of the next, the first and the last beyond it).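

In this assay, for the compounds shown here, compound 4 gives the first reading at this position with an oxygen rather than a saturated carbon joining the ring to the aromatic carbon of the shared core. Set against its closest partner, 4-fluorophenoxy in place of 4-fluorobenzyl gives a 1.9-fold higher number from compound 2 to compound 4 (0.27 log units; within the scatter), so exchanging the linking atom alone is not resolved from the scatter, while 4-fluorophenoxy in place of 2-chloro-4-fluorobenzyl gives a 2.7-fold higher number from compound 3 to compound 4 (0.43 log units; beyond the scatter), a step that combines the loss of the chloro with the new link. 4-Fluorophenoxy in place of isopentyl gives a 7.4-fold higher number from compound 1 to compound 4 (0.87 log units; beyond the scatter), so compound 1 now stands beyond the scatter from all three compounds that carry a ring at this position.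

The compounds shown leave open whether a sulfur or an amine nitrogen as the linking atom, or a longer chain between the ring and the core, would give numbers near those of compound 2 and compound 4. They also leave open what a chloro would do on the ring of compound 4, and nothing at hand explains the size or direction of these steps.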